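This account rests on a few compounds, and the source may have more. Where it says the series, first, only, none or still open, it means among the compounds named here.

Compound 1, `CCc1nc(N)nc(N)c1-c1ccc(NCc2ccc(S(C)(=O)=O)cc2)cc1`, is the more potent of the two measured compounds in a functional assay on CHOK cells for antagonist activity at growth hormone secretagogue receptor type 1 (Homo sapiens), read by calcium flux; a higher number here means a weaker inhibitor, a lower number a stronger inhibitor. In this assay compound 1 gives 12 nM. Among the measured compounds shown here, its only measured neighbour is compound 2, `CCc1nc(N)nc(N)c1-c1ccc(NCc2ccc(C(C)=O)cc2)cc1`, which in this assay gives 110 nM; the step of a 9.2-fold higher number from compound 1 to compound 2 (0.96 log units; beyond the scatter) shows how much the half-maximal inhibitory concentration shifts when the methylsulfonyl group is exchanged for acetyl.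

Compound 3, `CCc1nc(N)nc(N)c1-c1ccc(NCc2ccc(S(C)(=O)=O)cc2)c(Br)c1`, keeps the methylsulfonyl group and the shared core of compound 1 and differs from it only by bromo in place of hydrogen on an aromatic carbon, set on the aromatic carbon that is ortho to a large group and meta to a large group. For the measured compounds named here, none of the measured steps touches this position or this kind of change; the single measured step concerns the exchange of the methylsulfonyl group at the other end of the molecule and so bears on compound 3 only indirectly, as a reminder that the series can move by a step of the size of a 9.2-fold higher number from compound 1 to compound 2 (0.96 log units; beyond the scatter) with one change.

Going by the values given here, with no directly relevant step, the expected change from compound 1 is estimated at a 1.3-fold higher number from compound 1 to compound 3 (0.10 log units; within the scatter), within or close to the scatter. Compound 3 is therefore estimated to give 15 nM in this assay, with a likely range from 4 nM to 60 nM.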

Compound 3, half-maximal inhibitory concentration: 42 nM
Compound 3: middle estimate off by 2.8-fold (0.45 log units), on the low side; low and high end bracket the measured number.
By their numbers in this assay, from the lowest: compound 1; then compound 3; then compound 2.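

Among the compounds shown here, the result gives the first measured reading at this position: in this assay, bromo in place of hydrogen on an aromatic carbon that is ortho to a large group and meta to a large group gives a step beyond the scatter (a 3.5-fold higher number from compound 1 to compound 3 (0.54 log units; beyond the scatter)). The earlier compounds shown here showed a change only at the methylsulfonyl end, whereas this step shows that the number also responds to a change on the other aromatic ring, here the entry of one bromine atom with no hydrogen-bond donor, no hydrogen-bond acceptor and no net charge, and compound 1 remains the most potent of the three. No measurement at hand explains why bromo at this position gives a higher number than hydrogen.

The compounds shown leave open whether this step is particular to bromo or would also appear with fluoro, chloro, methyl, methoxy or an amine at the same carbon. They also leave open whether bromo would give a step of similar size with acetyl in place of methylsulfonyl, or at another carbon of the same ring.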